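Acetylation of the side-chain hydroxyl in a chloropurine

This account rests on a few compounds, and the source may have more. Where it says the series, first, only, none or still open, it means among the compounds named here.

Compound 1 `Nc1nc(=O)n(COCCO)cc1[N+](=O)[O-]`: in a functional assay on L1210 cells (Mus musculus) for inhibition (a lower number here means a stronger inhibitor, a higher number a weaker inhibitor), compound 1 gives > 500 ug/mL, a limit of the assay.
Compound 2 `Nc1nc(Cl)c2ncn(COCCO)c2n1`: in this assay compound 2 gives > 1000 ug/mL, also a limit of the assay.

Compound 2 stands at the limit of > 1000 ug/mL in this assay, at which 1 of the 2 values shown sits, and compound 1 sits at the limit of > 500 ug/mL in this assay, at which 1 of the 2 values shown sits. Neither value is a number, so no ordering between them can be drawn. Compound 3 `CC(=O)OCCOCn1cnc2c(Cl)nc(N)nc21` differs from compound 2 by acetyl in place of hydrogen on an oxygen on a saturated carbon. Going by the values given here, no measured step covers this change. The expected step of a number no higher from compound 2 to compound 3 (the limit leaves the size open) is none beyond the scatter. Compound 3 is therefore estimated at 1000 ug/mL, with a range from 300 ug/mL to 3000 ug/mL, and most likely the assay again reports only a limit.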

Compound 3, concentration for 50% inhibition: > 1000 ug/mL
Compound 3: a limit, no number; the forecaster's own chance of this, stated with the estimate: 85%; the middle value sits exactly at the limit.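

In this assay compound 3 gives > 1000 ug/mL, a limit of the assay. Going by these compounds alone, compound 2 gives > 1000 ug/mL, also a limit, so no step between compound 2 and compound 3 can be read. The compounds shown leave open whether acetyl in place of hydrogen changes inhibition at all.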